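The source may report more compounds than this note shows. Statements on the series, on what has been measured and on what is new or still open speak of the compounds shown alone.

Measured so far in an assay on CHO cells for binding affinity to 5-hydroxytryptamine receptor 1D (Homo sapiens); a lower number here means a stronger inhibitor, a higher number a weaker inhibitor:

- compound 1 `OCCC(NC1CCN(CCCc2c[nH]c3ccc(-n4cnnc4)cc23)CC1)c1ccccc1`: 5.5 nM
- compound 2 `NC(=O)OC[C@H](NC1CCN(CCCc2c[nH]c3ccc(-n4cnnc4)cc23)CC1)c1ccccc1`: 4.7 nM

Going by the values given here, compound 2 and compound 1 cannot be told apart on these two numbers: the single measured step, a 1.2-fold lower number from compound 1 to compound 2 (0.07 log units; within the scatter), lies within the scatter. Compound 2 therefore stands together with compound 1, not apart from it.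

Compound 3 `CC(=O)Nc1ccc([C@@H](C)NC2CCN(CCCc3c[nH]c4ccc(-n5cnnc5)cc34)CC2)cc1` is not yet measured. It differs from compound 2 at the same amine nitrogen that was varied before: 1-(4-acetamidophenyl)ethyl in place of 2-(carbamoyloxy)-1-phenylethyl on an amine nitrogen. Among the compounds with values here, the only measured step that bears on it is the earlier exchange at this position, a 1.2-fold lower number from compound 1 to compound 2 (0.07 log units; within the scatter), which changed the group on the amine nitrogen and moved the number within the scatter. Within the data shown here, no measured pair carries an acetamidophenyl group, and none replaces the phenyl-bearing side chain as completely as this, so the evidence is thin and indirect.

On that basis no step beyond the scatter is expected, with a wide range to reflect the uncertainty. For compound 3 the expected value in this assay is 8 nM, range 2 nM to 40 nM. The expected step of a 1.7-fold higher number from compound 2 to compound 3 (0.23 log units; within the scatter) is therefore small.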

Compound 3, half-maximal inhibitory concentration: 29 nM
Compound 3: middle estimate off by 3.6-fold (0.56 log units), on the low side; the measured number falls inside the stated range.
By their numbers in this assay, from the lowest: compounds 2 and 1 (each within the scatter of the next); then compound 3.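

In this assay the group on the amine nitrogen can now be seen to move the number beyond the scatter, with a 6.2-fold higher number from compound 2 to compound 3 (0.79 log units; beyond the scatter) and a 5.3-fold higher number from compound 1 to compound 3 (0.72 log units; beyond the scatter) both modest in size, whereas the exchange between compound 1 and compound 2 stayed within the scatter. The position therefore does not treat all phenyl-bearing groups alike: 1-(4-acetamidophenyl)ethyl separates from both 3-hydroxy-1-phenylpropyl and 2-(carbamoyloxy)-1-phenylethyl, even though it matches the latter in heavy atom count and in its single aromatic ring, so those counts do not account for the difference. No measurement available here explains the rise in the number.

The compounds shown leave open which part of the exchange carries the step, the acetamido group on the phenyl ring or the loss of the oxygen-bearing side chain, as the two differ together in compound 3. A plain 1-phenylethyl group would help to separate the two, and a 1-(4-aminophenyl)ethyl group would show whether the ring substituent needs its acetyl part.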